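The compounds below may be only part of what the source reports. "The series", "measured", "known", "first", "only" and "open" are said of these compounds alone.

Measured in an ADME assay on cells for inhibition of Amine oxidase [flavin-containing] A (Homo sapiens), read by spectrophotometry; on this read-out lower numbers stand for stronger inhibition and higher numbers for weaker inhibition:
compound 1 `S=C(Nc1ccccc1)Nc1ccc2[nH]ccc2c1` gives 57500 nM
compound 2 `Oc1ccccc1NC(=S)Nc1ccc2[nH]ccc2c1` gives 14000 nM
compound 3 `COc1ccc(NC(=S)Nc2ccc3[nH]ccc3c2)cc1` gives 36000 nM

Compound 3 stands second highest of the three numbers. Its nearest neighbour is compound 1, a gap within the scatter; compound 2 lies furthest from it, a gap beyond the scatter. The two steps from compound 1 set this out: a 1.6-fold lower number from compound 1 to compound 3 (0.20 log units; within the scatter) and a 4.1-fold lower number from compound 1 to compound 2 (0.61 log units; beyond the scatter).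

Compound 4 `CC(=O)Nc1ccc(NC(=S)Nc2ccc3[nH]ccc3c2)cc1` is still to be measured. Against compound 3 the change is acetamido in place of methoxy on an aromatic carbon; the entering group carries a hydrogen-bond donor that the leaving group lacked.

Within the data shown here, two measured steps bear on this change. The step of a 1.6-fold lower number from compound 1 to compound 3 (0.20 log units; within the scatter) shows that methoxy on this ring moves the number little. The step of a 4.1-fold lower number from compound 1 to compound 2 (0.61 log units; beyond the scatter) shows that adding a group with a hydrogen-bond donor gives a modest lowering, though in compound 2 that group is hydroxy rather than acetamido. On this basis the acetamido is expected to lower the number against compound 3 by a modest amount, possibly no further than the scatter. The expected step is a 1.8-fold lower number from compound 3 to compound 4 (0.26 log units; within the scatter). For compound 4 the estimate in this assay is 20000 nM, with a range of 7000 nM to 60000 nM.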

Compound 4, half-maximal inhibitory concentration: 70000 nM
Compound 4: middle estimate off by 3.5-fold (0.54 log units), on the low side; measured number outside the range, above it.
By their numbers in this assay, from the lowest: compound 2; then compounds 3, 1 and 4 (each within the scatter of the next).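

In this assay, acetamido para to a large group gives a 1.9-fold higher number from compound 3 to compound 4 (0.29 log units; within the scatter) and also a 1.2-fold higher number from compound 1 to compound 4 (0.09 log units; within the scatter), so hydrogen, methoxy and acetamido in this place are not told apart on this read-out. Among these compounds, the hydrogen-bond donor of the acetamido therefore brings no lowering beyond the scatter here, and the only step of this kind remains the hydroxy step (a 4.1-fold lower number from compound 1 to compound 2 (0.61 log units; beyond the scatter)); compound 2 and compound 4 differ in more than one place, so that step does not transfer directly to the acetamido. Nothing at hand accounts for this flat result.

Open, from the compounds shown here alone, is whether a smaller donor-bearing group, such as an amine or a hydroxy, would move the number beyond the scatter in this same place, and whether a carboxylic acid or a longer chain on the amide would do so. Also open, going by these compounds, is whether the lowering in compound 2 belongs to the hydroxy itself or to the carbon that carries it.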